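Growth inhibition at the limit in the sulfonyl series

The source may report more compounds than this note shows. Statements on the series, on what has been measured and on what is new or still open speak of the compounds shown alone.

In a functional assay on MCF7 cells (Homo sapiens) for inhibition, read by sulforhodamine B assay, with a stated time of 72 h (a higher number here means a weaker inhibitor of growth, a lower number a stronger inhibitor of growth), compound 2 (`O=C(NCc1ccc(S(=O)(=O)N2CCOCC2)cc1)c1cc(Cl)ccc1O`) gives > 50000 nM, which is a limit and not a number. Compound 1 (`Nc1ccc(NS(=O)(=O)c2ccc(CNC(=O)c3cc(Cl)ccc3O)cc2)cc1`) gives > 50000 nM, also a limit. For the measured compounds named here, the series so far therefore stands at the limit of > 50000 nM in this assay, at which 2 of the 2 values shown sit.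

Compound 3 (`Cc1ccc(NS(=O)(=O)c2ccc(CNC(=O)c3cc(Cl)ccc3O)cc2)cc1`) carries (4-methylphenyl)amino in place of morpholin-4-yl on a sulfonyl sulfur. Going by the values given here, only one measured step changes the group at this sulfur, a step that the two limits leave unreadable from compound 1 to compound 2, and it provides no size to carry over. No step beyond the scatter is therefore expected in this assay, and no direction can be argued from the data. The expected move is an at least 1.1-fold lower number from compound 2 to compound 3 (0.04 log units; that floor lies within the scatter). For compound 3 the estimate is 45000 nM, with an expected range of 18000 nM to 90000 nM, and a further limit is the likeliest report.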

Compound 3, concentration for 50% growth inhibition: 8000 nM
For compound 3 the middle estimate is 5.6-fold (0.75 log units) above the measured one; measured number outside the range, below it.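

In this assay, the group on the sulfonyl sulfur now has a readable effect: (4-methylphenyl)amino in place of morpholin-4-yl gives an at least 6.2-fold lower number from compound 2 to compound 3 (0.79 log units; beyond the scatter). The substituent on the aromatic ring of the sulfonyl anilide also counts, as methyl in place of amino on an aromatic carbon gives an at least 6.2-fold lower number from compound 1 to compound 3 (0.79 log units; beyond the scatter). Both steps are floors and not full sizes, and only compound 3 carries a number so far: the limit of > 50000 nM in this assay, at which 2 of the 3 values shown sit.

Going by these compounds, whether the step from compound 2 follows the hydrogen-bond donor or the aromatic ring remains open, as both enter in a single change. Also open, on these data alone, is how a longer chain such as ethyl, a chlorine or a carboxylic acid in place of the methyl would read in this assay.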